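Threonine amide series: acylation of the free amine

The source may report more compounds than this note shows. Statements on the series, on what has been measured and on what is new or still open speak of the compounds shown alone.

The three measured compounds share the core of compound 1 `CCCCCCCCCCCCCCNC(=O)[C@@H](N)[C@@H](C)O`. In a functional assay on A-431 cells (Homo sapiens) for cytotoxicity, read by MTT assay, with a stated time of 48 h (on this read-out lower numbers stand for stronger inhibition and higher numbers for weaker inhibition), compound 1 gives 14600 nM, which stands at the low end of the three numbers, all of them within the scatter of one another. Compound 2 `CCCCCCCCCCCCCCCCCCNC(=O)[C@@H](N)[C@@H](C)O` gives 21300 nM in this assay, and the step of a 1.5-fold higher number from compound 1 to compound 2 (0.16 log units; within the scatter). Among the compounds with values here, compound 3 `CCCCCCCCCCCCNC(=O)[C@@H](NC(=O)c1cccs1)[C@@H](C)O` gives 16600 nM in this assay; it differs from compound 1 in two places, so no single step connects them, and its number and that of compound 1 are within the scatter of each other.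

Compound 4 `CCCCCCCCCCCCCCNC(=O)[C@@H](NC(=O)/C=C/c1ccccc1)[C@@H](C)O` is not yet measured. It differs from compound 1 by (2-phenylethenyl)carbonyl in place of hydrogen on an amine nitrogen. Within the data shown here, no measured step changes this place. Among the measured compounds shown here, the one step available, a 1.5-fold higher number from compound 1 to compound 2 (0.16 log units; within the scatter), concerns the chain and stays within the scatter. Compound 3 carries a carbonyl substituent on the same amine nitrogen together with a shorter chain, and its number in this assay sits close to that of compound 1. On these grounds no step beyond the scatter is expected for compound 4 in this assay. The step expected in this assay is a 1.0-fold higher number from compound 1 to compound 4 (0.01 log units; within the scatter). Compound 4 is therefore estimated at 15000 nM in this assay, with a range from 6000 nM to 40000 nM.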

Compound 4, half-maximal inhibitory concentration: 64900 nM
Compound 4: the middle estimate sits 4.3-fold (0.64 log units) below what was measured; measured number outside the range, above it.
By their numbers in this assay, from the lowest: compounds 1, 3 and 2 (each within the scatter of the next); then compound 4.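

In this assay, within the data shown here, (2-phenylethenyl)carbonyl in place of hydrogen on the amine nitrogen gives a 4.4-fold higher number from compound 1 to compound 4 (0.65 log units; beyond the scatter), the first single change at this position with a step of its own and the first step beyond the scatter. The amine nitrogen is therefore not indifferent to substitution in this assay, at least for this group, whereas the chain change gives a 1.5-fold higher number from compound 1 to compound 2 (0.16 log units; within the scatter) and stays within the scatter. No measurement on hand bears on the reason for this step, which stands as an observation only.

The compounds shown do not say which part of the entering group carries the step: the aromatic ring, the double bond or the carbonyl, and a plain acetyl group or a benzoyl group on the same amine nitrogen of the core of compound 1 would begin to separate these. Compound 3 differs from compound 1 in two places, so it leaves open how other carbonyl substituents on this nitrogen behave at a fixed chain length, and whether a shorter or longer chain alters the step seen here.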